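This account rests on a few compounds, and the source may have more. Where it says the series, first, only, none or still open, it means among the compounds named here.

The set shares one core, seen in compound 1 `Cc1ccccc1OS(=O)(=O)c1ccc(N2CCN(C)C2=O)cc1`, which in a functional assay on M21 cells (Homo sapiens) for antiproliferative activity, read by sulforhodamine B assay, with a stated time of 48 h (on this read-out lower numbers stand for stronger inhibition and higher numbers for weaker inhibition), gives 2900 nM. Compound 2 `CN1CCN(c2ccc(S(=O)(=O)Oc3cccc([N+](=O)[O-])c3)cc2)C1=O` carries a different aryl group on the oxygen bound to the sulfonyl sulfur and in this assay gives 23000 nM. Among the measured compounds shown here, compound 3 `CCCN1CCN(c2ccc(S(=O)(=O)Oc3ccccc3C)cc2)C1=O` is the only member whose result is not a number. In this assay compound 3 reaches only the limit of > 100000 nM, a limit and nothing more; that bound is the limit of > 100000 nM in this assay, at which 1 of the 3 values shown sits. For the measured compounds named here, the single measured step, an at least 34-fold higher number from compound 1 to compound 3 (1.53 log units; beyond the scatter), is an ethyl in place of hydrogen on a saturated chain carbon bound to an amide-type nitrogen in a ring, and it is large. Compound 4 `CCCN1CCN(c2ccc(S(=O)(=O)Oc3cccc(Cl)c3)cc2)C1=O` keeps the chain of compound 3 and differs from it in one place: 3-chlorophenyl in place of 2-methylphenyl on an oxygen. Going by the values given here, no measured step bears on this exchange; compounds 1 and 2 differ at the same oxygen, but their values stand alone without a paired step. Since compound 3 already sits at the limit, the step from compound 3 to compound 4 is expected to be about a number no higher from compound 3 to compound 4 (the limit leaves the size open), no movement beyond the scatter. Compound 4 is therefore expected to give roughly 100000 nM in this assay, within a range from 20000 nM to 300000 nM, with a fair chance that only a limit is reported.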

Compound 4, half-maximal inhibitory concentration: 8600 nM
Compound 4: the middle estimate sits 12-fold (1.07 log units) above what was measured; measured number below the stated range.
By their numbers in this assay, from the lowest: compound 1; then compound 4; then compound 2. At a limit, above all of these: compound 3.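

Among the compounds shown here, the exchange of 2-methylphenyl for 3-chlorophenyl on the oxygen bound to the sulfonyl sulfur brings an at least 11-fold lower number from compound 3 to compound 4 (1.06 log units; beyond the scatter) in this assay, the first paired step at this position, and it shows that the aryl group there can by itself move the result by a large amount. The chain of compound 3 therefore does not by itself settle the result, since compound 4 keeps that chain and gives 8600 nM. The true size of the step remains open, and its printed size is only a bound, because compound 3 is known only through a limit: the limit of > 100000 nM in this assay, at which 1 of the 4 values shown sits.

The two aryl groups differ in both substituent and its printed ring position, so the effect of replacing methyl with chlorine cannot be separated from the effect of that position, and 2-chlorophenyl and 3-methylphenyl on the same oxygen would be the groups to tell these apart. As far as these compounds go, it also remains open how an amine or a carboxylic acid on this aryl ring would read in this assay, and whether a longer chain on the amide-type nitrogen would still leave room for the effect of 3-chlorophenyl.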